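Chalcone series on cytotoxicity: a nitro for dichloro swap

The source may report more compounds than this note shows. Statements on the series, on what has been measured and on what is new or still open speak of the compounds shown alone.

Measured so far:
compound 1 `CNC(=O)c1cc(Oc2ccc(C(=O)/C=C/c3ccc(Cl)c(Cl)c3)cc2)ccn1` — 13200 nM
compound 2 `CNC(=O)c1cc(Oc2ccc(C(=O)/C=C/c3ccc(F)cc3)cc2)ccn1` — 28500 nM
compound 3 `CNC(=O)c1cc(Oc2ccc(/C=C/C(=O)c3ccc(Cl)cc3)cc2)ccn1` — 17500 nM

In a functional assay on MCF7 cells (Homo sapiens) for cytotoxicity, read by MTT assay, with a stated time of 72 h (on this read-out lower numbers stand for stronger inhibition and higher numbers for weaker inhibition), compound 1 sits at the low end of the three numbers. Compound 3 falls within the usual scatter of compound 1, so the two cannot be separated. Compound 2 lies further off: a 2.2-fold higher number from compound 1 to compound 2 (0.33 log units; beyond the scatter).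

Compound 4 `CNC(=O)c1cc(Oc2ccc(C(=O)/C=C/c3cccc([N+](=O)[O-])c3)cc2)ccn1` has not been measured. It differs from compound 1 in one place: 3-nitrophenyl in place of 3,4-dichlorophenyl on a double-bonded chain carbon bound to a double-bonded chain carbon. Among the compounds with values here, the only measured step that bears on a change at this position is the one from compound 1 to compound 2, where a 4-fluorophenyl replaced the 3,4-dichlorophenyl and the number rose modestly. Within the data shown here, no step with a nitro-bearing ring is available, so the direction for compound 4 rests on that single comparison and on the shared core, which otherwise stays fixed.

For compound 4 a small rise in the number, of about the size seen with compound 2, is expected: a 1.5-fold higher number from compound 1 to compound 4 (0.18 log units; within the scatter). The estimate for compound 4 in this assay is 20000 nM, with a range from 8000 nM to 50000 nM.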

Compound 4, half-maximal inhibitory concentration: > 50000 nM
Compound 4 ended at the assay's limit; the forecaster's own chance of this, stated with the estimate: 10%; at least 2.5-fold (0.39 log units) between middle value and limit.
By their numbers in this assay, from the lowest: compounds 1, 3 and 2 (each within the scatter of the next, the first and the last beyond it). At a limit, above all of these: compound 4.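

In this assay compound 4 stands at a limit of the assay and not at a number: the limit of > 50000 nM in this assay, at which 1 of the 4 values shown sits. The change to 3-nitrophenyl gives an at least 3.7-fold higher number from compound 1 to compound 4 (0.57 log units; beyond the scatter), and the read-out leaves the measurable range, which the 4-fluorophenyl of compound 2 did not do, so a single ring change at this place on the chain can carry the series out of that range. Against the 4-fluorophenyl ring the result is an at least 1.7-fold higher number from compound 2 to compound 4 (0.24 log units; that floor lies within the scatter), so these two rings are not firmly separated.

Still open, on these data alone, is how far past the limit compound 4 lies, and whether the change follows the entering nitro group or the departure of the two chlorines. A 3-chlorophenyl or 3-aminophenyl ring at the same place on the chain would help separate these two readings.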